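The compounds below may be only part of what the source reports. "The series", "measured", "known", "first", "only" and "open" are said of these compounds alone.

Of the compounds shown here, three have been measured in an ADME assay on the whole organism (thoracic aorta) with Rattus norvegicus as the target; a lower number here means a smaller maximal response, a higher number a larger maximal response. Compound 1 `Cc1ccc(CC2=NCCN2)cc1` gives 5%, compound 2 `O=C(CI)Nc1ccc(CC2=NCCN2)cc1` gives 13%, and compound 3 `S=C=Nc1ccc(Cc2ncc[nH]2)cc1` gives 68%, the highest of the three. Among the measured compounds shown here, the only step between neighbours, a number 8 percentage points higher from compound 1 to compound 2 (within the scatter), concerns a different part of the molecule and does not bear on the change now followed. Compound 4 `S=C=Nc1ccc(CC2=NCCN2)cc1` differs from compound 3 by a group of 5 heavy atoms (3 carbon, 2 nitrogen; one five-membered non-aromatic ring with 2 hetero atoms) in place of a group of 5 heavy atoms (3 carbon, 2 nitrogen; one five-membered aromatic ring with 2 hetero atoms), on a saturated chain carbon bound to an aromatic carbon. For the measured compounds named here, no measured step follows this change, but compounds 1 and 2, which carry the entering group, both gave low numbers. Compound 4 is therefore expected to lie below compound 3, at an estimated 30% with a range of 5% to 65%. The expected step is a number 38 percentage points lower from compound 3 to compound 4 (beyond the scatter), though with considerable uncertainty.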

Compound 4, largest response reached (Emax), in percent of the reference or control that the assay uses: 100%
Compound 4: the middle estimate sits 70 percentage points below what was measured, outside the stated range (above it).
By their numbers in this assay, from the lowest: compounds 1 and 2 (each within the scatter of the next); then compound 3; then compound 4.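

In this assay the five-membered non-aromatic ring, put in place of 1H-imidazol-2-yl on a saturated chain carbon bound to an aromatic carbon, goes with a larger maximal response, with a number 32 percentage points higher from compound 3 to compound 4 (beyond the scatter). The entering ring therefore does not give low numbers by itself: with this ring kept, the group on an aromatic carbon makes a large difference, with a number 87 percentage points higher from compound 2 to compound 4 (beyond the scatter) and a number 95 percentage points higher from compound 1 to compound 4 (beyond the scatter). No evidence is available to explain these steps.

On these data alone, whether an amine or a carboxylic acid on that aromatic carbon would also give a large response remains open. So does the effect of a longer chain between the aromatic carbon and the ring.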